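Swapping the chain amine on a naphthalene sulfonamide carbamate

This account rests on a few compounds, and the source may have more. Where it says the series, first, only, none or still open, it means among the compounds named here.

The measured compounds are:
compound 1 `CCCC(=O)N1CCC(NS(=O)(=O)c2ccc(NC(=O)CC3CCCC3)c3ccccc23)CC1`, 145 nM in an in vitro functional assay on CHO/Galpha16 cells for antagonist activity at C-C chemokine receptor type 8 (Homo sapiens), read by FLIPR; a lower number here means a stronger inhibitor, a higher number a weaker inhibitor
compound 2 `CCCC(=O)N1CCC(NS(=O)(=O)c2ccc(NC(=O)C(CC)CC)c3ccccc23)CC1`, 639 nM
compound 3 `Cc1ccccc1C(=O)Nc1ccc(S(=O)(=O)NC2CCN(C(=O)OCCCN(C)C)CC2)c2ccccc12`, 9.8 nM

Compound 3 gives the lowest of the three numbers in this assay. For the measured compounds named here, compound 1 sits well behind it, and compound 2 further still; the one step between measured compounds, a 4.4-fold higher number from compound 1 to compound 2 (0.64 log units; beyond the scatter), concerns the group on the carbonyl carbon of the amide and lies beyond the scatter.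

Compound 4 `Cc1ccccc1C(=O)Nc1ccc(S(=O)(=O)NC2CCN(C(=O)OCCCN3CCCC3)CC2)c2ccccc12` differs from compound 3 elsewhere: pyrrolidin-1-yl in place of dimethylamino on a saturated chain carbon, three bonds along the chain from an oxygen next to a carbonyl group. Going by the values given here, nothing measured so far touches this part of the molecule. The step of a 4.4-fold higher number from compound 1 to compound 2 (0.64 log units; beyond the scatter) changed a different position, so it gives no direct guide, and the carbamate chain is otherwise unvaried among the three compounds. With no evidence either way, compound 4 is expected to stay close to compound 3, the step of a 1.0-fold higher number from compound 3 to compound 4 (0.01 log units; within the scatter) being within the scatter or not far beyond it. Compound 4 is therefore estimated at 10 nM, with a range from 4 nM to 25 nM.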

Compound 4, half-maximal inhibitory concentration: 4.2 nM
Beside the measured number, compound 4's estimate is 2.4-fold (0.38 log units) above it; the measured number falls inside the stated range.
By their numbers in this assay, from the lowest: compound 4; then compound 3; then compound 1; then compound 2.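

For the compounds shown here, the step of a 2.3-fold lower number from compound 3 to compound 4 (0.37 log units; beyond the scatter) in this assay is the first reading at this position, since the earlier step changed only the group on the carbonyl carbon of the amide. It shows that the chain amine is not indifferent to its substituents: tying the dimethylamino group into the pyrrolidin-1-yl ring gives a modest gain beyond the scatter, and the potency of this series is kept. Nothing available accounts for this gain.

The compounds shown leave open whether a larger ring such as piperidin-1-yl, a morpholine, or a ring-free diethylamino group would follow the same direction at this position. They also leave open whether the gain would hold on a shorter 2-(pyrrolidin-1-yl)ethyl chain, or with a different amide group on the shared core.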